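The source may hold more compounds than are shown below. What is called first, only, known or untested is meant among the compounds shown, and "the series" means these compounds.

Three compounds carry the same core, a six-membered aromatic ring with one nitrogen, bearing three hydroxyphenyl groups that differ only in where the hydroxyl sits on each outer ring. Compound 1 `Oc1ccc(-c2cc(-c3cccc(O)c3)cc(-c3cccc(O)c3)n2)cc1` carries two 3-hydroxyphenyl groups and one 4-hydroxyphenyl group. Compound 2 `Oc1ccc(-c2cc(-c3cccc(O)c3)cc(-c3ccccc3O)n2)cc1` and compound 3 `Oc1ccc(-c2cc(-c3ccccc3O)nc(-c3ccccc3O)c2)cc1` each carry a 2-hydroxyphenyl group, and how their cores differ is not broken down here.

In a functional assay on DU-145 cells (Homo sapiens) for cytotoxicity, read by CCK-8 assay, with a stated time of 4 days (on this read-out lower numbers stand for stronger inhibition and higher numbers for weaker inhibition), compound 1 gives 1940 nM. For compound 2 this assay reports only a limit, > 50000 nM. For compound 3 this assay likewise reports only a limit, > 50000 nM. The change from compound 2 to compound 1 3-hydroxyphenyl in place of 2-hydroxyphenyl on an aromatic carbon brings an at least 25-fold lower number from compound 2 to compound 1 (1.41 log units; beyond the scatter).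

Compound 4 `Oc1ccc(-c2cc(-c3cccc(O)c3)nc(-c3ccccc3O)c2)cc1` is not yet measured. It arises from compound 3 by the same kind of change (3-hydroxyphenyl in place of 2-hydroxyphenyl on an aromatic carbon), although here the place sits meta to a 2-hydroxyphenyl group rather than meta to a 3-hydroxyphenyl group, and a 2-hydroxyphenyl group remains in compound 4. Because compound 2 sits at the limit of > 50000 nM in this assay, at which 2 of the 3 values shown sit, while still carrying one 2-hydroxyphenyl group, a value near that limit is expected for compound 4 as well. The expected step from compound 3 to compound 4 in this assay is an at least 1.2-fold lower number from compound 3 to compound 4 (0.09 log units; that floor lies within the scatter), and the estimate for compound 4 in this assay is 40000 nM, expected to lie between 8000 nM and 120000 nM.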

Compound 4, half-maximal inhibitory concentration: 3420 nM
Compound 4: the middle estimate sits 12-fold (1.07 log units) above what was measured, outside the stated range (below it).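

Putting a 3-hydroxyphenyl group in place of a 2-hydroxyphenyl group brings, in this assay, an at least 14-fold lower number from compound 3 to compound 4 (1.16 log units; beyond the scatter), so the large drop seen earlier with the same change on a different core appears here too, even though a 2-hydroxyphenyl group remains in the product. Compound 3, the starting point of this step, is reported only as a limit, > 50000 nM. The true size of each step therefore stays unknown, and the data do not show that the change is worth more on one core than on the other: the same change on two cores in this assay, an at least 25-fold lower number (1.41 log units; beyond the scatter) from compound 2 to compound 1 and an at least 14-fold lower number (1.16 log units; beyond the scatter) from compound 3 to compound 4; the limit leaves it open whether they differ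

Every compound shown carries a hydroxyl group on all three outer rings, and these hydroxyl groups differ only in where they sit, so it remains open whether each of them is needed at all, or whether an amine, a carboxylic acid or a methoxy group could take the place of the hydroxyl on the 3-hydroxyphenyl group and still give a low number. As far as these compounds go, it is also open whether the same change would carry over to a core with a different ring in the centre, or to cell types other than the one used here.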